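Two analogues at the assay limit and an untested third

The compounds below may be only part of what the source reports. "The series", "measured", "known", "first", "only" and "open" are said of these compounds alone.

Compound 1 `COc1ccc(S(=O)(=O)Nc2ccc3oc(-c4ccc(NC(=O)c5ccc(Cl)s5)cc4)nc3c2)cc1` gives > 100000 nM in an assay on isolated protein for inhibition of thiosulfate sulfurtransferase (Homo sapiens); a lower number here means a stronger inhibitor, a higher number a weaker inhibitor; this value is a limit of the assay, not a number.
Compound 2 `COc1ccc(S(=O)(=O)Nc2ccc3oc(-c4ccc(NS(=O)(=O)c5cc(F)ccc5OC)cc4)nc3c2)cc1` gives > 100000 nM in this assay; this too is a limit.

Compound 2 therefore stands at the limit of this assay, with no number of its own, and compound 1 sits at the same limit (the limit of > 100000 nM in this assay, at which 2 of the 2 values shown sit). Among the measured compounds shown here, the only measured step, a step that the two limits leave unreadable from compound 1 to compound 2, cannot be read in size or direction, since both ends are limits. Compound 3 `COc1ccc(S(=O)(=O)Nc2ccc3oc(-c4ccc(NC(=O)C5CCN(C(C)=O)CC5)cc4)nc3c2)cc1` differs from compound 2 by a group of 11 heavy atoms (8 carbon, 1 nitrogen, 2 oxygen; one six-membered non-aromatic ring with 1 hetero atom) in place of a group of 12 heavy atoms (7 carbon, 3 oxygen, 1 fluorine, 1 sulfur; one six-membered aromatic ring of carbon only), on a nitrogen on an aromatic ring. No readable step bears on this change, so the expectation rests only on where compound 2 stands. Compound 3 is expected to remain at or near the limit, with a step from compound 2 of a number no higher from compound 2 to compound 3 (the limit leaves the size open) that is estimated as no change beyond the scatter. The estimated value for compound 3 is 100000 nM, within a range from 30000 nM to 300000 nM, most likely reported again only as a limit.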

Compound 3, half-maximal inhibitory concentration: > 100000 nM
Compound 3 ended at the assay's limit; the forecaster's own chance of this, stated with the estimate: 80%; the middle value lies on the limit itself.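

Compound 3 sits at a limit of this assay, as compound 1 and compound 2 do, so no step among the three compounds can be read: the limit of > 100000 nM in this assay, at which 3 of the 3 values shown sit.

The compounds shown leave open whether any group on that nitrogen of the shared core can give a readable value in this assay.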